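Swapping Halogens on a Weak Tryptophan Dioxygenase Inhibitor

A few compounds are considered here, and "the series" means these few. Any claim that something is new, unique, unknown or untested is made for them only; others in the source may bear on it.

Compound 1 `O=[N+]([O-])c1ccc(N/C(=N\O)c2ccccc2Br)c2nonc12`: 25000 nM
Compound 2 `O=[N+]([O-])c1ccc(N/C(=N\O)c2cccc(Br)c2)c2nonc12`: 20000 nM

Of the compounds shown here, two have so far been measured in an assay on isolated protein for inhibition of Tryptophan 2,3-dioxygenase (Homo sapiens), read by spectrophotometry, with a stated time of 1 h; a higher number here means a weaker inhibitor, a lower number a stronger inhibitor. Compound 1 gives 25000 nM in this assay, and compound 2 gives 20000 nM. Of the two numbers, that of compound 2 is the lowest, but the step of a 1.3-fold lower number from compound 1 to compound 2 (0.10 log units; within the scatter) is within the scatter, so the two compounds cannot be told apart on this evidence.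

Compound 3 `O=[N+]([O-])c1ccc(N/C(=N\O)c2ccc(Cl)cc2)c2nonc12` has not yet been measured in this assay. It differs from compound 2 in a single place: 4-chlorophenyl in place of 3-bromophenyl on a carbon with a double bond to nitrogen. Among the compounds with values here, the only measured step also exchanged one bromophenyl for another, and a 1.3-fold lower number from compound 1 to compound 2 (0.10 log units; within the scatter) stayed within the scatter. Within the data shown here, that step bears on the present change only in part, and no measured pair compares a bromine with a chlorine on this ring. With nothing pointing to a shift in either direction, no step beyond the scatter is expected for compound 3, and the estimated step is no change at the digits printed from compound 2 to compound 3 (within the scatter). Compound 3 is therefore expected to give about 20000 nM in this assay, with a range from 8000 nM to 50000 nM.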

Compound 3, half-maximal inhibitory concentration: 40000 nM
Compound 3: middle estimate off by 2.0-fold (0.30 log units), on the low side; low and high end bracket the measured number.
By their numbers in this assay, from the lowest: compounds 2, 1 and 3 (each within the scatter of the next).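

In this assay, the ring on the carbon with a double bond to nitrogen now carries chlorine as well as bromine, and the three readings remain inseparable: 4-chlorophenyl in place of 3-bromophenyl gives a 2.0-fold higher number from compound 2 to compound 3 (0.30 log units; within the scatter), and 4-chlorophenyl in place of 2-bromophenyl gives a 1.6-fold higher number from compound 1 to compound 3 (0.20 log units; within the scatter). Neither the kind of halogen nor its place on the ring separates these three compounds, although 4-chlorophenyl differs from each bromophenyl in both respects at once, so the two changes cannot be judged apart. Nothing available here speaks to why the readings fall where they do.

Going by these compounds, all three compounds carry a single halogen on this ring, so it remains open whether a different kind of group here, such as an amine, a carboxylic acid or a methoxy group, would move the number beyond the scatter. Also open, on these data alone, is whether 4-bromophenyl or 3-chlorophenyl, either of which would let the halogen and its place be compared one at a time, would read any differently.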